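Compound 2 to compound 4: losing the amino link

The compounds below may be only part of what the source reports. "The series", "measured", "known", "first", "only" and "open" are said of these compounds alone.

compound 1 `C=C[C@@](C)(/C=C/c1ccc(Nc2ccc(F)cc2)cc1)CCC=C(C)C`: > 36600 nM (a limit)
compound 2 `C=C[C@@](C)(/C=C/c1ccc(Nc2ccc(Cl)c(F)c2)cc1)CCC=C(C)C`: > 36600 nM (a limit)
compound 3 `C=C[C@@](C)(/C=C/c1ccc(Nc2cc(F)c(F)cc2F)cc1)CCC=C(C)C`: > 36600 nM (a limit)

In an ADME assay on HEK293 cells (Homo sapiens) for cytotoxicity, with a stated time of 72 h (a higher number here means that more compound is needed for the effect, a lower number that less compound is needed), compound 2 gives only a limit (> 36600 nM). Going by the values given here, it has no number to rank it by, and the same goes for the whole series so far (the limit of > 36600 nM in this assay, at which 3 of the 3 values shown sit).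

Compound 4 `C=C[C@@](C)(/C=C/c1ccc(-c2ccc(Cl)c(Cl)c2)cc1)CCC=C(C)C` carries 3,4-dichlorophenyl in place of (4-chloro-3-fluorophenyl)amino on an aromatic carbon, para to a large group (3,4-dichlorophenyl in place of (4-chloro-3-fluorophenyl)amino on an aromatic carbon). Among the compounds with values here, the nitrogen leaves with that group, and no measured step removes it. The closest evidence changes only the ring on the nitrogen: a step that the two limits leave unreadable from compound 1 to compound 2 together with a step that the two limits leave unreadable from compound 1 to compound 3 and also a step that the two limits leave unreadable from compound 2 to compound 3 among the compounds at hand. None of these has a readable size, so they give neither a magnitude nor a direction for the new change. What they do show is that all three ring variants end at the limit of this assay and none gives a number. The estimate for the change is a step that the limit leaves unreadable from compound 2 to compound 4 with no firm direction expected. Compound 4 is estimated at 40000 nM with an expected range from 15000 nM to 100000 nM and a report of only a limit is the likely outcome.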

Compound 4, half-maximal effective concentration: > 36600 nM
Compound 4 ended at the assay's limit (the forecaster's own chance of this, stated with the estimate: 75%); the middle value lies beyond the limit too.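

Compound 4 also ends as a limit in this assay, so no step from compound 1 or compound 2 to compound 4 can be read: the limit of > 36600 nM in this assay, at which 4 of the 4 values shown sit.

The compounds shown leave open whether the amino link or the substitution on the ring carried by the nitrogen changes the read-out in this assay at all.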